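One Amide Substituent Change on a Shared Lipid Core

A few compounds are considered here, and "the series" means these few. Any claim that something is new, unique, unknown or untested is made for them only; others in the source may bear on it.

Compound 1, `CCCCCCCCCCCC(=O)OC[C@H](CSC[C@@H](N)C(=O)NCCCC(C)(C)CO)OC(=O)CCCCCCCCCCC`: 30700 nM
Compound 2, `CCCCCCCCCCCC(=O)OC[C@H](CSC[C@@H](N)C(=O)NCCCCCCCCCC(=O)O)OC(=O)CCCCCCCCCCC`: 4400 nM

Both compounds were tested in an assay on HEK293 cells for agonist activity at Toll-like receptor 2 (Homo sapiens); a higher number here means that more compound is needed for the effect, a lower number that less compound is needed. Compound 2 holds the lowest number of the two, and its nearest neighbour is compound 1, which sits a clear distance above it: a 7.0-fold lower number from compound 1 to compound 2 (0.84 log units; beyond the scatter). Among the measured compounds shown here, this is the only measured step, and it concerns the group carried by the amide-type nitrogen, the same place that is altered in the next compound.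

Compound 3, `CCCCCCCCCCCC(=O)OC[C@H](CSC[C@@H](N)C(=O)NC(C)CCN(CC)CC)OC(=O)CCCCCCCCCCC`, differs from compound 2 in exactly that spot: 3-(diethylamino)-1-methylpropyl in place of 9-carboxynonyl on an amide-type nitrogen. The acid-bearing chain of compound 2 is gone and a diethylamino-bearing chain takes its place. For the measured compounds named here, no measured pair shows what such an exchange does. Going by the values given here, what can be said is that the one step available, the move from compound 1 to compound 2, shows that the amide substituent alone can shift the number well beyond the scatter, and that compound 2 is the better of the two measured compounds with the carboxylic group present. Its removal in compound 3 is therefore expected to cost potency, with a 4.5-fold higher number from compound 2 to compound 3 (0.66 log units; beyond the scatter) as the estimated step, though with wide uncertainty. Compound 3 is estimated at 20000 nM, within the range 5000 nM to 80000 nM.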

Compound 3, half-maximal effective concentration: 257 nM
The estimate for compound 3 lay 78-fold (1.89 log units) above the measured number; measured number below the stated range.
By their numbers in this assay, from the lowest: compound 3; then compound 2; then compound 1.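

In this assay, the carboxylic acid of compound 2 proves dispensable at the amide-type nitrogen: replacing 9-carboxynonyl with 3-(diethylamino)-1-methylpropyl gives a 17-fold lower number from compound 2 to compound 3 (1.23 log units; beyond the scatter), so the number falls rather than rises when the acid-bearing chain leaves. Measured against the 4-(hydroxymethyl)-4-methylpentyl group of compound 1, the same substituent gives a 120-fold lower number from compound 1 to compound 3 (2.08 log units; beyond the scatter), which shows that this one position can move the number over a wider span than the earlier step, a 7.0-fold lower number from compound 1 to compound 2 (0.84 log units; beyond the scatter), had revealed. The material at hand offers no measured account of why this exchange has such an effect.

The exchange alters several things together, including the chain, its 1-methyl branch and the diethylamino group, so the compounds shown cannot assign the drop in the number to any one of them. Going by these compounds, a 3-(diethylamino)propyl group without the branch, a 3-(dimethylamino)-1-methylpropyl group or a 9-aminononyl chain on the same nitrogen would be the kinds of substituent needed to pull those features apart, and how any of them would behave remains open.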